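This account rests on a few compounds, and the source may have more. Where it says the series, first, only, none or still open, it means among the compounds named here.

Working notes on the series.

Compound 1 is `COc1cc(N)c(Cl)cc1NC(=O)C1CCN(Cc2ccc([N+](=O)[O-])cc2)CC1`. In a functional assay on the whole organism for antagonist activity, with Mus musculus as the target (a higher number here means that more compound is needed for the effect, a lower number that less compound is needed), compound 1 gives > 4 mg/kg, which is a limit of the assay and not a number. Compound 2, `COc1cc(N)c(Cl)cc1NC(=O)C1CCN(Cc2ccc(OCc3ccccc3)cc2)CC1`, is the benzyloxy-for-nitro analogue; in this assay compound 2 gives > 4 mg/kg, again a limit. Compound 3, `CCC(CC)CN1CCC(C(=O)Nc2cc(Cl)c(N)cc2OC)CC1`, carries pentan-3-yl on the saturated chain carbon bound to the ring amine nitrogen; in this assay compound 3 gives > 10 mg/kg, also a limit. The two measured steps, a step that the two limits leave unreadable from compound 1 to compound 2 and a step that the two limits leave unreadable from compound 1 to compound 3, cannot be sized, since all three values sit at limits: the limit of > 4 mg/kg in this assay, at which 2 of the 3 values shown sit, (the limit of > 10 mg/kg in this assay, at which 1 of the 3 values shown sits).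

Compound 4 is `COc1cc(N)c(Cl)cc1NC(=O)C1CCN(Cc2ccc(C)c(C)c2)CC1`. It differs from compound 1 as follows: 3,4-dimethylphenyl in place of 4-nitrophenyl on a saturated chain carbon bound to an amine nitrogen in a ring. Neither measured step bears readably on this change; both leave the size open. Compound 4 is therefore expected to sit at a limit as well, with the step that the limit leaves unreadable from compound 1 to compound 4 unreadable. The estimate for compound 4 in this assay is 10 mg/kg, between 4 mg/kg and 30 mg/kg.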

Compound 4, dose for half-maximal effect: > 8 mg/kg
Compound 4 was reported as a limit (the forecaster's own chance of this, stated with the estimate: 80%); the middle value is on the limit's open side.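

In this assay compound 4 gives > 8 mg/kg, a limit of the assay and not a number, so the steps to compound 4 from compound 1 and from compound 3 cannot be read. The compounds shown leave open whether the substituents on the amine nitrogen in a ring differ at all in this read-out.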